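Adding Fluoro to the Trifluoromethyl Ring

The source may hold more compounds than are shown below. What is called first, only, known or untested is meant among the compounds shown, and "the series" means these compounds.

compound 1, `Fc1ccccc1Nc1nc2nonc2nc1Nc1cccc(F)c1F`: 500 nM
compound 2, `Fc1ccccc1Nc1nc2nonc2nc1Nc1cccc(C(F)(F)F)c1`: < 1000 nM

Of the compounds shown here, two have been measured in an assay on mitochondria from L6 cells (Rattus norvegicus) for activation, with a stated time of 90 min; a lower number here means that less compound is needed, a higher number that more compound is needed for the effect. Compound 1, `Fc1ccccc1Nc1nc2nonc2nc1Nc1cccc(F)c1F`, gives 500 nM. Compound 2, `Fc1ccccc1Nc1nc2nonc2nc1Nc1cccc(C(F)(F)F)c1`, gives only < 1000 nM, which is a limit of the assay rather than a number. Compound 2 thus stands at the limit of < 1000 nM in this assay, at which 1 of the 2 values shown sits, so its place among the numbers is not fixed. Among the measured compounds shown here, no step between measured compounds that differ in one place is available. Compound 3, `Fc1ccccc1Nc1nc2nonc2nc1Nc1cccc(C(F)(F)F)c1F`, is not yet measured; it differs from compound 2 by fluoro in place of hydrogen on an aromatic carbon. Compound 2 is known only as a limit. For the measured compounds named here, the expectation for compound 3 therefore rests on compound 1, whose 500 nM is the one number given. Compound 3 is expected to show about 400 nM, within a range from 100 nM to 1500 nM. The step this implies, a step that the limit leaves unreadable from compound 2 to compound 3, is expected to stay within the scatter.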

Compound 3, half-maximal effective concentration: < 370 nM
Compound 3: a limit, no number; the forecaster's own chance of this, stated with the estimate: 20%; middle value at least 1.0-fold (0.03 log units) from the limit.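

In this assay compound 3 is recorded only as a limit of the assay, not as a number: the limit of < 370 nM in this assay, at which 1 of the 3 values shown sits. Trifluoromethyl in place of fluoro gives an at least 1.3-fold lower number from compound 1 to compound 3 (0.13 log units; that floor lies within the scatter), the first step among these compounds that can be read at all, though it is known only as a floor. The step between the two compounds that carry trifluoromethyl cannot be read, so the limit gives no size for fluoro in place of hydrogen at this position, ortho to a trifluoromethyl group.

As far as these compounds go, the actual numbers for compound 2 and compound 3 remain open, and with them the size of that change. Also open, from the compounds shown here alone, is how a methoxy group or an amine on this same aromatic carbon would read in place of fluoro.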